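The compounds below may be only part of what the source reports. "The series", "measured", "known", "first", "only" and "open" are said of these compounds alone.

Measured so far in an assay on LX2 cells for inhibition of COL1A1 promoter (Homo sapiens), read by a luciferase reporter, with a stated time of 24 h, tested at 50 uM; on this read-out higher numbers stand for a stronger effect at the one concentration tested and lower numbers for a weaker effect:

compound 1 `Cc1cc(OCCCCCCC[N+]2(C)CCCC2)cc(-n2cc(C(=O)Nc3cc(F)cc(F)c3)c(=O)c3ccc(N(C)C)nc32)c1`: 35.4%
compound 2 `Cc1cc(-n2cc(C(=O)Nc3cc(F)cc(F)c3)c(=O)c3ccc(N(C)C)nc32)ccc1OCCCCCCC[N+]1(C)CCCCC1`: 54.4%

Of the two numbers, compound 1 stands lowest; its nearest neighbour is compound 2, whose number lies higher by a margin beyond the usual scatter. Among the measured compounds shown here, no single-point step between these two measured compounds is on record, as compound 2 also differs from compound 1 in how the chain is attached to the core, so only the two values themselves can be compared.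

The next compound, compound 3 `Cc1cc(OCCCCCCC[N+](C)(C)C2CCCCC2)cc(-n2cc(C(=O)Nc3cc(F)cc(F)c3)c(=O)c3ccc(N(C)C)nc32)c1`, is not yet measured in this assay. Relative to compound 1 the change is a group of 9 heavy atoms (8 carbon, 1 nitrogen; one six-membered non-aromatic ring of carbon only) in place of a group of 6 heavy atoms (5 carbon, 1 nitrogen; one five-membered non-aromatic ring with 1 hetero atom), on a saturated chain carbon, seven bonds along the chain from an oxygen on an aromatic ring. The charged end of the chain is kept, the core of compound 1 is unchanged, and nothing in the measured pair speaks directly to a swap of this kind.

For the measured compounds named here, with no comparable step available, the expected step of a number 4.6 percentage points higher from compound 1 to compound 3 (within the scatter) is set small, within the scatter, leaning slightly upward. For compound 3 the estimate in this assay is 40%, with a range from 22% to 58%.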

Compound 3, a percentage reported as inhibition, at one concentration (the size of the read-out at that concentration, not a potency): 89.1%
Compound 3: middle estimate off by 49.1 percentage points, on the low side; measured number outside the range, above it.
By their numbers in this assay, from the lowest: compound 1; then compound 2; then compound 3.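

In this assay, putting the group with one six-membered non-aromatic ring of carbon only in place of the group with one five-membered non-aromatic ring with 1 hetero atom gives a number 53.7 percentage points higher from compound 1 to compound 3 (beyond the scatter). The end of the chain, on a saturated chain carbon, seven bonds along the chain from an oxygen on an aromatic ring, is therefore not a silent position: with the core of compound 1 unchanged, this single change moves the read-out by a large margin. Both groups carry a net charge of +1 and count no hydrogen-bond donors or acceptors, so those counts do not separate them, and nothing measured here says what does.

The pair does not show whether the step follows from the larger ring, from the ring holding only carbon, or from the greater number of heavy atoms, and a dimethylcyclopentylammonium or a trimethylammonium end group would help to separate these. Also open is whether the charge is needed at all, a question that a neutral tertiary amine at the same chain end would address, and the single-concentration read-out gives no potency for any of these compounds.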